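Notes on the N-aryl series: compound 3 to compound 4

The compounds below may be only part of what the source reports. "The series", "measured", "known", "first", "only" and "open" are said of these compounds alone.

In a functional assay on cells for positive allosteric modulation of metabotropic glutamate receptor 5 (Rattus norvegicus), read by calcium flux (on this read-out lower numbers stand for an effect already at smaller amounts and higher numbers for an effect only at larger amounts of compound), compound 1 `O=C(Nc1cc(-c2ccccc2)nn1-c1ccccc1Cl)c1ccccc1` gives 62 nM. Compound 2 `O=C(Nc1cc(-c2ccccc2)nn1-c1ccccc1Br)c1ccccc1` gives 200 nM, and compound 3 `N#Cc1cccc(-n2nc(-c3ccccc3)cc2NC(=O)c2ccccc2)c1` gives 117 nM. Compound 3 sits between the other two on these numbers: a 1.9-fold higher number from compound 1 to compound 3 (0.28 log units; within the scatter) and a 1.7-fold lower number from compound 2 to compound 3 (0.23 log units; within the scatter), both within the scatter, whereas the halogen exchange gives a 3.2-fold higher number from compound 1 to compound 2 (0.51 log units; beyond the scatter), a modest step.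

Compound 4 `COc1cccc(-n2nc(-c3ccccc3)cc2NC(=O)c2ccccc2)c1` differs from compound 3 by methoxy in place of cyano on an aromatic carbon. Within the data shown here, no measured step exchanges the cyano group itself, so nothing directly bears on this change. Among the measured compounds shown here, what is known is that altering the group on the aromatic nitrogen has so far given only small movements, a 1.9-fold higher number from compound 1 to compound 3 (0.28 log units; within the scatter) and a 1.7-fold lower number from compound 2 to compound 3 (0.23 log units; within the scatter), and that the one step beyond the scatter, a 3.2-fold higher number from compound 1 to compound 2 (0.51 log units; beyond the scatter), is of modest size. On this basis the step expected in this assay is a 1.1-fold higher number from compound 3 to compound 4 (0.05 log units; within the scatter), with no clear direction and probably not beyond the scatter. Compound 4 is therefore estimated at 130 nM, with a range from 45 nM to 400 nM.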

Compound 4, half-maximal effective concentration: 570 nM
Compound 4: the middle estimate sits 4.4-fold (0.64 log units) below what was measured; measured number above the stated range.
By their numbers in this assay, from the lowest: compounds 1, 3 and 2 (each within the scatter of the next, the first and the last beyond it); then compound 4.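

In this assay, the change at this aromatic carbon, meta to a large group, is not silent: a 4.9-fold higher number from compound 3 to compound 4 (0.69 log units; beyond the scatter), even though cyano and methoxy have the same counts of heavy atoms and hydrogen-bond acceptors. The aryl group on the aromatic nitrogen therefore matters more than the small steps among compound 1, compound 2 and compound 3 showed, since 3-methoxyphenyl also stands apart from both halogenated aryl groups, with a 2.9-fold higher number from compound 2 to compound 4 (0.45 log units; beyond the scatter) and a 9.2-fold higher number from compound 1 to compound 4 (0.96 log units; beyond the scatter). No available data give a reason for the step from cyano to methoxy.

Going by these compounds, how an amine, a carboxylic acid or a longer chain at this place would read remains open. Also open, on these data alone, is whether the step from cyano to methoxy keeps its size when other parts of the shared core change.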